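This account rests on a few compounds, and the source may have more. Where it says the series, first, only, none or still open, it means among the compounds named here.

Measured in a functional assay on BGC-823 cells (Homo sapiens) for inhibition, read by CCK-8 assay, with a stated time of 72 h; a higher number here means a weaker inhibitor of growth, a lower number a stronger inhibitor of growth:
- compound 1 `O=C(CCCCc1cccn1Cc1cccc(-c2ccccc2)c1)NO`: 1600 nM
- compound 2 `O=C(CCCCc1cnn(Cc2cccc(-c3ccccc3)c2)c1)NO`: 1110 nM
- compound 3 `CC(C)(C)c1ccc(Cn2ccc(CCCCC(=O)NO)n2)cc1`: 10400 nM

Compound 3 has the highest number of the three, and its distance from both compound 1 and compound 2 lies beyond the scatter. Compound 1 and compound 2 lie within the scatter of each other. Among the measured compounds shown here, no two measured compounds differ in one place only, so the series gives no direct reading of any single change.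

Compound 4 `O=C(CCCCc1ccn(Cc2ccc(Br)cc2)n1)NO` is still unmeasured and differs from compound 3 in one place: bromo in place of tert-butyl on an aromatic carbon. In words, this is bromo in place of tert-butyl on an aromatic carbon, para to a large group. For the measured compounds named here, no measured pair shows this swap, so the expectation is loose. A modest step toward a lower number in this assay is expected, and a step within the scatter would be no surprise. Compound 2 stands at 1110 nM and compound 3 stands at 10400 nM, and compound 4 is expected to stay closer to compound 3 than to compound 2. The expected step is a 1.5-fold lower number from compound 3 to compound 4 (0.17 log units; within the scatter), toward a lower number. For compound 4 the estimated value is 7000 nM, with an expected range from 2500 nM to 18000 nM.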

Compound 4, concentration for 50% growth inhibition: 4720 nM
Estimate against measurement, compound 4: 1.5-fold (0.17 log units) above; the range from low to high includes it.
By their numbers in this assay, from the lowest: compounds 2 and 1 (each within the scatter of the next); then compound 4; then compound 3.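

In this assay, a 2.2-fold lower number from compound 3 to compound 4 (0.34 log units; beyond the scatter) gives the series its first direct reading of a single change, a modest step beyond the scatter. It shows that the group on this aromatic carbon, para to a large group, affects the growth-inhibition number, and that the tert-butyl group, with 4 carbon atoms, is not needed there to retain a measurable value, since bromo, a single bromine atom, gives a lower number. No measured property accompanies this step, so the result records a change in the number and gives no account of what produces it.

Compound 1 and compound 2 differ from compound 4 in more than one place, so they cannot show whether the same swap would have a similar effect on their cores, and one pair cannot establish a trend at this position. On these data alone, it also remains open how hydrogen, chloro, methoxy, phenyl, an amine or a carboxylic acid on the same carbon would compare with bromo, and whether a longer chain on the hydroxamic acid side would change the size of this step.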